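Methyl in Place of Cyclopropyl at the Carbonyl Carbon

This account rests on a few compounds, and the source may have more. Where it says the series, first, only, none or still open, it means among the compounds named here.

Measured compounds:
- compound 1 `O=C(C1CC1)N1CCN(c2nc(=O)c3cc(C(F)(F)F)cc([N+](=O)[O-])c3s2)CC1`: > 125000 nM
- compound 2 `O=C(C1CCCCC1)N1CCN(c2nc(=O)c3cc(C(F)(F)F)cc([N+](=O)[O-])c3s2)CC1`: 88700 nM
- compound 3 `CC(C)(C)C1CCC(C(=O)N2CCN(c3nc(=O)c4cc(C(F)(F)F)cc([N+](=O)[O-])c4s3)CC2)CC1`: > 125000 nM

In an ADME assay on Vero cells (Chlorocebus sabaeus) for cytotoxicity, read by MTT assay, with a stated time of 72 h (on this read-out higher numbers stand for lower toxicity in this test and lower numbers for higher toxicity in this test), compound 1 gives > 125000 nM, which is a limit of the test rather than a number. Compound 3 likewise gives > 125000 nM, again a limit. Within the data shown here, compound 2 gives 88700 nM, the only full number among the three. Compound 1 therefore stands at the top of what the test can report, as described by the limit of > 125000 nM in this assay, at which 2 of the 3 values shown sit.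

The three compounds share one core and differ only in the group on the carbonyl carbon. Going from compound 1 to compound 2 means cyclohexyl in place of cyclopropyl, with an at least 1.4-fold lower number from compound 1 to compound 2 (0.14 log units; that floor lies within the scatter). Going from compound 2 to compound 3 means tert-butyl in place of hydrogen on a saturated ring carbon, with an at least 1.4-fold higher number from compound 2 to compound 3 (0.14 log units; that floor lies within the scatter). The step that the two limits leave unreadable from compound 1 to compound 3 cannot be read from two limits.

Compound 4 `CC(=O)N1CCN(c2nc(=O)c3cc(C(F)(F)F)cc([N+](=O)[O-])c3s2)CC1` is not yet measured. Its change from compound 1 is methyl in place of cyclopropyl on a carbonyl carbon, the reverse direction of the growth seen from compound 1 to compound 2. Since that enlargement gave a step within the scatter, compound 4 is expected to show a step that the limit leaves unreadable from compound 1 to compound 4, no change beyond the scatter. The estimate for compound 4 is 150000 nM, between 70000 nM and 300000 nM, most likely reported again as a limit.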

Compound 4, half-maximal cytotoxic concentration: > 125000 nM
Compound 4 ended at the assay's limit; the forecaster's own chance of this, stated with the estimate: 65%; the middle value lies beyond the limit too.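

Compound 4 shows that the group on this carbonyl carbon can shrink to methyl and the result in this assay still stays at the limit of the test, as it did with cyclopropyl and 4-(tert-butyl)cyclohexyl, leaving the cyclohexyl of compound 2 as the one exception: the limit of > 125000 nM in this assay, at which 3 of the 4 values shown sit. Methyl in place of cyclohexyl gives an at least 1.4-fold higher number from compound 2 to compound 4 (0.14 log units; that floor lies within the scatter), so this floor alone does not separate the two compounds. The steps that link compound 4 with compound 1 and compound 3 cannot be read, as each joins two limits.

The compounds shown leave open whether a group carrying an amine or a carboxylic acid, or a longer chain, on this carbonyl carbon would bring the number clearly down in this assay. They also leave open how far the true values of compound 1, compound 3 and compound 4 lie past the limit, and whether these three compounds differ from one another at all.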